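The source may report more compounds than this note shows. Statements on the series, on what has been measured and on what is new or still open speak of the compounds shown alone.

Measured so far:
- compound 1 `C=CCCCCOc1ccccc1-c1cnc(OCCC=C)n1C`: 33000 nM
- compound 2 `C=CCCCCOc1ccc(F)cc1-c1cnc(OCCC=C)n1C`: 73000 nM

Among the measured compounds shown here, in a functional assay on U-373MG ATCC cells (Homo sapiens) for inhibition, read by colorimetric assay and MTT assay, with a stated time of 72 h (on this read-out lower numbers stand for stronger inhibition and higher numbers for weaker inhibition), compound 1 gives 33000 nM, the lower of the two numbers so far. For the measured compounds named here, the only measured step is a 2.2-fold higher number from compound 1 to compound 2 (0.34 log units; beyond the scatter), with fluoro in place of hydrogen on an aromatic carbon.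

Compound 3 `C=CCCOc1ncc(-c2ccccc2OC)n1C` has no value yet. Its change from compound 1 is hydrogen in place of pent-4-en-1-yl on a saturated chain carbon bound to an oxygen on an aromatic ring. In other words, hydrogen stands in place of pent-4-en-1-yl on a saturated chain carbon bound to an oxygen on an aromatic ring, which reads (hex-5-en-1-yl)oxy to methoxy when cut one bond further out.

Going by the values given here, no measured step touches this chain, so the fluoro step serves only as a rough scale and says nothing firm on direction. A modest move towards a higher number in this assay is expected, since compound 1 at 33000 nM is already the lower of the two values, but this is a weak lean. The expected change is a 1.8-fold higher number from compound 1 to compound 3 (0.26 log units; within the scatter). The estimated value for compound 3 is 60000 nM, with a wide expected range from 22000 nM to 160000 nM.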

Compound 3, half-maximal inhibitory concentration: 16000 nM
Compound 3: middle estimate off by 3.8-fold (0.57 log units), on the high side, and the stated range ends above it.
By their numbers in this assay, from the lowest: compound 3; then compound 1; then compound 2.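

In this assay, among the compounds shown here, the change from (hex-5-en-1-yl)oxy to methoxy gives a 2.1-fold lower number from compound 1 to compound 3 (0.31 log units; beyond the scatter) and so moves the number down, which makes this the first measured step at this place on the series. The pent-4-en-1-yl portion, with its double bond, is therefore not needed to reach the values seen so far, and compound 3 at 16000 nM holds the lowest number of the three compounds shown, while the earlier fluoro step concerned another place and gave no reading on this chain. Nothing at hand bears on why the number falls with the shorter group.

As far as these compounds go, with only the two chain ends in hand, it remains open whether the number changes steadily or passes through a minimum across intermediate groups such as ethoxy, propoxy or butoxy, and whether a saturated hexyloxy chain would read like the hex-5-en-1-yl one. Also open, from the compounds shown here alone, are a free hydroxyl or an amine-bearing chain at this place, and whether the fluoro step seen on compound 1 carries over to the methoxy compound.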